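Aminoethyl amine exchanged for an aminopropanoyl amide

The source may report more compounds than this note shows. Statements on the series, on what has been measured and on what is new or still open speak of the compounds shown alone.

compound 1: `CC(C)C[C@H](N)c1cc(C(F)(F)F)ccc1N1CCN(C(=O)CCc2ccc(O)cc2)CC1` — > 10000 nM
compound 2: `CCC(C)[C@H](NCCN)c1cc(C(F)(F)F)ccc1N1CCN(C(=O)CCc2ccc(Cl)cc2Cl)CC1` — 56 nM

In an assay on HEK293 cells for displacement of a labelled ligand from Melanocortin receptor 4 (Homo sapiens) (a higher number here means a weaker inhibitor, a lower number a stronger inhibitor), compound 1 reaches only a limit, > 10000 nM, the situation summed up by the limit of > 10000 nM in this assay, at which 1 of the 2 values shown sits. Going by the values given here, compound 2 gives 56 nM, the only actual number among the two values shown. Compound 3, `CC(C)C[C@H](NC(=O)CCN)c1cc(C(F)(F)F)ccc1N1CCN(C(=O)CCc2ccc(Cl)cc2Cl)CC1`, differs from compound 2 by 1-(((2-aminoethyl)carbonyl)amino)-3-methylbutyl in place of 1-((2-aminoethyl)amino)-2-methylbutyl on an aromatic carbon. Among the compounds with values here, no pair of measured compounds differing in a single place exists, so nothing measured fixes the size of this step; a modest loss in this assay is expected. Compound 3 is estimated at 300 nM, with a range from 50 nM to 3000 nM, which is expected to amount to a 5.4-fold higher number from compound 2 to compound 3 (0.73 log units; beyond the scatter).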

Compound 3, inhibition constant: 25 nM
Compound 3: middle estimate off by 12-fold (1.08 log units), on the high side, and the stated range ends above it.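

In this assay, the exchange brings a 2.2-fold lower number from compound 2 to compound 3 (0.35 log units; beyond the scatter), so at this aromatic carbon the 1-((2-aminoethyl)amino)-2-methylbutyl group can give way to the 1-(((2-aminoethyl)carbonyl)amino)-3-methylbutyl group without a loss. Nothing measured here gives a cause for this step. The exchange combines a new carbonyl with a moved methyl branch, and the compounds shown do not separate the two. Also open, from the compounds shown here alone, is whether a longer chain before the terminal amine, or a carboxylic acid in place of that amine, would hold this level.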